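The compounds below may be only part of what the source reports. "The series", "measured", "known", "first", "only" and "open" are said of these compounds alone.

Working notes on the series. Compound 1 `CC(C)c1ccc(-c2nc(CN3CCCC3)nn2C)cc1` has been measured in an assay on membranes from Jurkat cells for displacement of a labelled ligand from Sigma non-opioid intracellular receptor 1 (Homo sapiens), read by scintillation counting, with a stated time of 2 h (on this read-out higher numbers stand for weaker inhibition and lower numbers for stronger inhibition), where compound 1 gives 96 nM. Within the data shown here, the only other member measured so far is compound 2 `Cn1nc(CN2CCCC2)nc1-c1ccc2ccsc2c1`, which in this assay gives 64 nM. Compound 1 therefore carries the highest of the two numbers, but the two values lie within the usual scatter of each other, so nothing separates them. Among the measured compounds shown here, no pair of measured compounds differs in a single place, so no single-change step is available as a guide.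

Compound 3 `Cn1nc(CN2CCCC2)nc1-c1ccc(C2(C(F)(F)F)CC2)cc1` has not yet been measured in this assay. It differs from compound 1 in one place: 1-(trifluoromethyl)cyclopropyl in place of isopropyl on an aromatic carbon. For the measured compounds named here, with no measured step of this kind to lean on, the expectation rests only on compound 1 at 96 nM. The expected step in this assay is a 1.3-fold lower number from compound 1 to compound 3 (0.11 log units; within the scatter), which is not expected to go beyond the scatter. For compound 3 in this assay the estimate is 75 nM, with a range from 25 nM to 220 nM.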

Compound 3, inhibition constant: 9.9 nM
For compound 3 the middle estimate is 7.6-fold (0.88 log units) above the measured one; measured number outside the range, below it.
By their numbers in this assay, from the lowest: compound 3; then compounds 2 and 1 (each within the scatter of the next).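

In this assay, among these compounds, the change from isopropyl to 1-(trifluoromethyl)cyclopropyl on the aromatic carbon para to a large group gives a 9.7-fold lower number from compound 1 to compound 3 (0.99 log units; beyond the scatter) and provides the first single-change step, showing that this position is not indifferent to the group it carries. The entering group is larger, with 7 heavy atoms against 3 and a three-membered ring, and this larger group is accompanied by stronger inhibition rather than a loss, while neither group has hydrogen-bond donors, hydrogen-bond acceptors or a net charge. No measurement here bears on the reason for this step.

Among the compounds shown here, the single step changes the ring and the trifluoromethyl group together, so their separate contributions remain open, and a plain cyclopropyl or a tert-butyl group at this place would be needed to tell them apart. Also open, from the compounds shown here alone, is how this position responds to a group of another kind, such as an amine or a carboxylic acid.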